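A few compounds are considered here, and "the series" means these few. Any claim that something is new, unique, unknown or untested is made for them only; others in the source may bear on it.

Compound 1 `O=C(O)c1ccccc1-c1ccc(CCc2ncc(-c3ccccc3)[nH]2)cc1` gives the highest of the three numbers seen in an in vitro functional assay on cells for agonist activity at Bombesin receptor subtype-3 (Mus musculus), read by luminescence and calcium flux (a higher number here means that more compound is needed for the effect, a lower number that less compound is needed), namely 872 nM. Compound 2 `CC(C)(C)CCc1cnc(CCc2ccc(-c3ccccc3C(=O)O)cc2)[nH]1` gives 6.2 nM, and compound 3 `Cc1ccc(Cc2cnc(CCc3ccc(-c4ccccc4C(=O)O)cc3)[nH]2)cc1` gives 162 nM. Compound 4 `CCC(C)(CC)Cc1cnc(CCc2ccc(-c3ccccc3C(=O)O)cc2)[nH]1` differs from compound 1 by 2-ethyl-2-methylbutyl in place of phenyl on an aromatic carbon. Going by the values given here, the steps that bear on this are those from compound 1 into the other two: a 140-fold lower number from compound 1 to compound 2 (2.15 log units; beyond the scatter) and a 5.4-fold lower number from compound 1 to compound 3 (0.73 log units; beyond the scatter); the branched chain entering in compound 4 is closest in kind to the 3,3-dimethylbutyl of compound 2, so a large drop in this assay is expected, of about an 87-fold lower number from compound 1 to compound 4 (1.94 log units; beyond the scatter). Compound 4 is therefore estimated at 10 nM in this assay, within a range of 3 nM to 40 nM.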

Compound 4, half-maximal effective concentration: 30 nM
Beside the measured number, compound 4's estimate is 3.0-fold (0.48 log units) below it, and the stated range covers the measured number.
By their numbers in this assay, from the lowest: compound 2; then compound 4; then compound 3; then compound 1.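

On the aromatic carbon of the five-membered ring, a second saturated branched chain, 2-ethyl-2-methylbutyl, also beats phenyl in this assay (a 29-fold lower number from compound 1 to compound 4 (1.46 log units; beyond the scatter)). It also improves on 4-methylbenzyl (a 5.4-fold lower number from compound 3 to compound 4 (0.73 log units; beyond the scatter)), yet falls short of 3,3-dimethylbutyl (a 4.8-fold higher number from compound 2 to compound 4 (0.68 log units; beyond the scatter)), so branched chains here are not interchangeable. No measurement in hand explains these steps.

Open, on these data alone, is whether an unbranched chain such as n-hexyl keeps the low number at this position. A chain ending in an amine or a hydroxyl also remains untested in the compounds shown.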